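Aryl group exchange on the oxygen in this sulfonamide series

The source may report more compounds than this note shows. Statements on the series, on what has been measured and on what is new or still open speak of the compounds shown alone.

Compound 3 `COc1cc2c(cc1OC)CN(S(=O)(=O)c1ccc(-n3cc(COc4ccccc4C)nn3)cc1)CC2` stands level with the other two compounds measured. In an assay on isolated protein for inhibition of Aromatase (Homo sapiens), read by fluorescence, with a stated time of 10 min, tested at 12.5 uM (a lower number here means less inhibition, a higher number more inhibition at the concentration tested (going by the name of the read-out)), compound 3 gives 14%; compound 1 `COc1cc2c(cc1OC)CN(S(=O)(=O)c1ccc(-n3cc(COc4ccccc4C(C)=O)nn3)cc1)CC2` gives 14% and compound 2 `COc1cc2c(cc1OC)CN(S(=O)(=O)c1ccc(-n3cc(COc4ccc([N+](=O)[O-])cc4)nn3)cc1)CC2` gives 14%. The steps of no change at the digits printed from compound 1 to compound 2 (within the scatter), no change at the digits printed from compound 1 to compound 3 (within the scatter) and no change at the digits printed from compound 2 to compound 3 (within the scatter) all lie within the scatter, so exchanging the group on the oxygen on a saturated carbon has not moved the inhibition so far. Compound 4 `COc1cc2c(cc1OC)CN(S(=O)(=O)c1ccc(-n3cc(COc4cc(C=O)ccc4OC)nn3)cc1)CC2` carries the change (5-formyl-2-methoxyphenyl in place of 2-methylphenyl on an oxygen on a saturated carbon). All three measured steps bear on it, since each swaps the group at this same place, and each was flat. For compound 4 the expected step in this assay is no change at the digits printed from compound 3 to compound 4 (within the scatter), none beyond the scatter. Compound 4 is estimated at 14%, with a range from 4% to 28%.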

Compound 4, a percentage reported as inhibition, at one concentration (the size of the read-out at that concentration, not a potency): 14%
Beside the measured number, compound 4's estimate shows no gap at the digits printed, and the stated range covers the measured number.
By their numbers in this assay, from the lowest: compounds 1, 2, 3 and 4 (each within the scatter of the next).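

In this assay the 5-formyl-2-methoxyphenyl group, with 10 heavy atoms and 2 hydrogen-bond acceptors, gives no change at the digits printed from compound 3 to compound 4 (within the scatter) and no change at the digits printed from compound 2 to compound 4 (within the scatter) and no change at the digits printed from compound 1 to compound 4 (within the scatter) as the three new readings. The flat picture at this place on the oxygen on a saturated carbon therefore now covers four aryl groups, including this one carrying both formyl and methoxy. No measurement at hand accounts for this flatness.

The compounds shown leave open whether an aryl group bearing a basic amine or a carboxylic acid would move the inhibition. As far as these compounds go, replacing the aryl ring with a longer saturated chain also remains untested here.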